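The source may hold more compounds than are shown below. What is called first, only, known or untested is meant among the compounds shown, and "the series" means these compounds.

Of the compounds shown here, three sharing one core have been tested in a functional assay on A549 cells (Homo sapiens) for inhibition, read by CCK-8 assay, with a stated time of 48 h; on this read-out lower numbers stand for stronger inhibition and higher numbers for weaker inhibition: compound 1 `COc1cc(-c2ccnc3cc(-c4ccccc4)nn23)cc(OC)c1OC` gives 208 nM, compound 2 `COc1cc(-c2ccnc3cc(-c4ccc(N(C)C)cc4)nn23)cc(OC)c1OC` gives 1100 nM, and compound 3 `COc1ccc(-c2cc3nccc(-c4cc(OC)c(OC)c(OC)c4)n3n2)cc1` gives 376 nM. Compound 3 thus sits level with compound 1 and clearly apart from compound 2. Compound 4 `CCOC(=O)c1ccc(-c2cc3nccc(-c4cc(OC)c(OC)c(OC)c4)n3n2)cc1` differs from compound 3 by one swap: ethoxycarbonyl in place of methoxy on an aromatic carbon. Two earlier changes at this place bear on it. Methoxy gave a 1.8-fold higher number from compound 1 to compound 3 (0.26 log units; within the scatter), while dimethylamino gave a 5.3-fold higher number from compound 1 to compound 2 (0.72 log units; beyond the scatter), and exchanging those two groups gave a 2.9-fold lower number from compound 2 to compound 3 (0.47 log units; beyond the scatter). Neither earlier group brought the number down, so a small upward move is expected, an estimated 1.5-fold higher number from compound 3 to compound 4 (0.17 log units; within the scatter). Compound 4 is expected near 550 nM, within an estimated range of 220 nM to 1400 nM.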

Compound 4, half-maximal inhibitory concentration: > 10000 nM
Compound 4 ended at the assay's limit; the forecaster's own chance of this, stated with the estimate: 2%; at least 18-fold (1.25 log units) between middle value and limit.
By their numbers in this assay, from the lowest: compounds 1 and 3 (each within the scatter of the next); then compound 2. At a limit, above all of these: compound 4.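

In this assay compound 4 stands at a limit and not at a number: the limit of > 10000 nM in this assay, at which 1 of the 4 values shown sits. Methoxy and dimethylamino at this place shifted the number only modestly, yet ethoxycarbonyl gives an at least 26-fold higher number from compound 3 to compound 4 (1.42 log units; beyond the scatter), and the other two comparisons read an at least 9.0-fold higher number from compound 2 to compound 4 (0.95 log units; beyond the scatter) and an at least 48-fold higher number from compound 1 to compound 4 (1.68 log units; beyond the scatter). This position therefore does not accept every group: one swap here can remove nearly all measurable inhibition, which compounds 2 and 3 did not reveal. From the compounds shown here alone, whether this holds for the ethyl ester alone or for related groups stays open; a carboxylic acid, an amide or a methyl ester at this place would address that.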